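A few compounds are considered here, and "the series" means these few. Any claim that something is new, unique, unknown or untested is made for them only; others in the source may bear on it.

Working notes on the series. Three compounds carry numbers in an assay on HEK293 cells for inhibition of Voltage-dependent T-type calcium channel subunit alpha-1H (Homo sapiens), read by patch clamp, using a membrane potential dye; a lower number here means a stronger inhibitor, a higher number a weaker inhibitor. Compound 1 `CC[C@H](C)[C@H](NC(=O)N1CCC2(CC1)CN(C)C2c1ccc(Cl)cc1)C(=O)OC` gives 410 nM in this assay. Compound 2 `CN1C(=O)C2(CCN(C(=O)Nc3cc(F)cc(F)c3)CC2)C1c1ccc(Cl)cc1` gives 920 nM in this assay. Compound 3 `COC(=O)[C@H](COC(C)(C)C)NC(=O)N1CCC2(CC1)C(=O)N(c1cccc(F)c1)C2c1ccc(Cl)cc1` gives 251 nM in this assay, the lowest of the three numbers; its gap to compound 1 lies within the usual scatter, so the two cannot be ordered, while its gap to compound 2 lies beyond the scatter. Within the data shown here, no step between measured compounds differs in one place, so nothing here isolates the effect of a single change.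

Compound 4 `CCC(C)NC(=O)N1CCC2(CC1)C(=O)N(c1cccc(F)c1)C2c1ccc(Cl)cc1` is not yet measured in this assay. Against compound 3 the change is sec-butyl in place of 1-(methoxycarbonyl)-2-(tert-butoxy)ethyl on an amide-type nitrogen. The urea substituent is stripped back to a plain branched alkyl group, with no acceptors left, on the shared core of compound 3. Among the measured compounds shown here, a step of this kind has no direct precedent, though compound 1, also an alkyl-bearing urea of a related core, sits close to compound 3 in this assay. The expectation for compound 4 is a modest movement to a higher number, a 2.0-fold higher number from compound 3 to compound 4 (0.30 log units; within the scatter), likely within or just at the edge of the scatter. The estimate for compound 4 is 500 nM, with a range of 200 nM to 1300 nM.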

Compound 4, half-maximal inhibitory concentration: 1250 nM
Beside the measured number, compound 4's estimate is 2.5-fold (0.40 log units) below it; measured number inside the range.
By their numbers in this assay, from the lowest: compounds 3 and 1 (each within the scatter of the next); then compounds 2 and 4 (each within the scatter of the next).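

Among these compounds, on the amide-type nitrogen of the shared core, sec-butyl in place of 1-(methoxycarbonyl)-2-(tert-butoxy)ethyl gives a 5.0-fold higher number from compound 3 to compound 4 (0.70 log units; beyond the scatter) in this assay; this is the first step that differs in one place, and it shows that the number at this position depends on the substituent carried there. The step is nevertheless a composite one: the leaving group has 11 heavy atoms, 3 hydrogen-bond acceptors, a double bond outside aromatic rings and a defined stereocentre, while sec-butyl has 4 heavy atoms, all carbon, and no acceptors, so the shift cannot be assigned to any one of these features. Nothing measured for these compounds accounts for the step.

Still open, from the compounds shown here alone, is which part of the leaving group matters: the methyl ester, the tert-butoxy ether or the defined stereocentre. Going by these compounds, a carboxylic acid in place of the methyl ester, a hydroxymethyl in place of the tert-butoxymethyl arm, or a longer plain alkyl chain in place of sec-butyl on the same nitrogen would each help separate these parts, and whether the step carries over to the cores of compound 1 and compound 2 also remains open.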